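This account rests on a few compounds, and the source may have more. Where it says the series, first, only, none or still open, it means among the compounds named here.

In an assay on the whole organism (plasma, strain Sprague-Dawley) for inhibition of Dipeptidyl peptidase 4 (Rattus norvegicus), with a stated time of 10 h, at a dose of 1 mg/kg by the oral route (a higher number here means more inhibition at the dose given (going by the name of the read-out), a lower number less inhibition), compound 1, `C[C@@H]1N[C@H](C(=O)N2CCC[C@H]2C#N)C[C@@H]1C(=O)N1CCSCC1`, gives 85%. Compound 2, `CN(C)C(=O)[C@@H]1CN[C@H](C(=O)N2CCC[C@H]2C#N)C1`, gives 52% in this assay, the lower of the two numbers, a gap to compound 1 that lies beyond the usual scatter. Compound 3, `C[C@@H]1N[C@H](C(=O)N2CCC[C@H]2C#N)C[C@@H]1C(=O)N(C)C`, differs from compound 2 by methyl in place of hydrogen on a saturated ring carbon. Within the data shown here, no such step has been measured here, so the expectation leans on compound 1, which also carries this methyl and reaches 85%. An upward step is expected, a number 14 percentage points higher from compound 2 to compound 3 (beyond the scatter), roughly midway between the two measured compounds. For compound 3 the estimate is 66%, expected between 46% and 84%.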

Compound 3, a percentage reported as inhibition, in the whole organism at one dose (the size of the read-out at that dose, not a potency): 84%
For compound 3 the middle estimate is 18 percentage points below the measured one; measured number inside the range.
By their numbers in this assay, from the lowest: compound 2; then compounds 3 and 1 (each within the scatter of the next).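

In this assay, methyl in place of hydrogen on this saturated ring carbon next to the ring nitrogen gives a number 32 percentage points higher from compound 2 to compound 3 (beyond the scatter) and so counts as a large step from a single added carbon. By contrast, dimethylamino in place of thiomorpholin-4-yl on a carbonyl carbon gives a number 1 percentage points lower from compound 1 to compound 3 (within the scatter) and so leaves the number within the scatter. Nothing given here accounts for the size of the methyl step. As far as these compounds go, it remains open whether an ethyl or a longer chain on this ring carbon would keep the higher number. From the compounds shown here alone, a carboxylic acid in place of the amide also remains untested in these compounds.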